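The source may report more compounds than this note shows. Statements on the series, on what has been measured and on what is new or still open speak of the compounds shown alone.

In an ADME assay on 184B5 cells (Homo sapiens) for cytotoxicity, read by sulforhodamine B assay, with a stated time of 48 h (on this read-out lower numbers stand for stronger inhibition of growth and higher numbers for weaker inhibition of growth), three compounds have been measured so far. Compound 1, with the structure `Cc1ccc2nc(/N=C3\C(=O)N(CN(C)C)c4ccccc43)sc2c1`, gives 15600 nM. Compound 2, whose structure is `Cc1ccc2nc(/N=C3\C(=O)N(CN(C)C)c4cccc(Cl)c43)sc2c1`, gives 5770 nM. Compound 3, a much smaller molecule with the structure `CN(C)CN1C(=O)C(=O)c2ccccc21`, gives 73700 nM, the highest of the three numbers.

Compound 1 and compound 2 differ in one place only: chloro in place of hydrogen on an aromatic carbon. That single change produced a 2.7-fold lower number from compound 1 to compound 2 (0.43 log units; beyond the scatter). Compound 3 and compound 1 are a different matter: the difference between the two cores is not broken down here, and their two values simply show that compound 3 stands well above compound 1.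

Compound 4, with the structure `CN(C)CN1C(=O)C(=O)c2c(Cl)cccc21`, has not yet been measured in this assay. It stands to compound 3 exactly as compound 2 stands to compound 1, since the change from compound 3 to compound 4 is chloro in place of hydrogen on an aromatic carbon, the same change that appears once before among these compounds. Whether a change that helped once on one core will help again on a smaller, different core is not something a single earlier example can settle, so some caution belongs in any forecast.

The expected outcome for the step from compound 3 to compound 4 is a 2.5-fold lower number from compound 3 to compound 4 (0.39 log units; beyond the scatter), a forecast that rests on the earlier pair because the same change gave a 2.7-fold lower number from compound 1 to compound 2 (0.43 log units; beyond the scatter). Compound 4 is therefore estimated at 30000 nM, with a likely range from 12000 nM to 75000 nM.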

Compound 4, concentration for 50% growth inhibition: 130000 nM
The estimate for compound 4 lay 4.3-fold (0.64 log units) below the measured number; measured number outside the range, above it.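

In this assay, chloro in place of hydrogen on an aromatic carbon gave a 1.8-fold higher number from compound 3 to compound 4 (0.25 log units; within the scatter), so the smaller core does not repeat the clear drop in the number seen on the larger core. Set side by side, the two results for this one change differ by more than repeat measurements would normally explain: the same change on two cores in this assay, a 2.7-fold lower number (0.43 log units; beyond the scatter) from compound 1 to compound 2 and a 1.8-fold higher number (0.25 log units; within the scatter) from compound 3 to compound 4, 4.8-fold (0.68 log units) apart, beyond the scatter of two such steps

Among these compounds, this shows that, across these two cores, the step measured on one core cannot simply be carried over as a fixed amount to the other, although it rests on only one pair of compounds for each core, and it does not show why the two cores respond differently or that chloro truly raises the number on the smaller core, since that step lies within the scatter.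

The compounds shown leave open whether other groups on this aromatic carbon, such as fluoro, bromo, methoxy or an amine, would also behave differently on the two cores. They also leave open what chloro would do on the other carbons of this six-membered aromatic ring, and which part of the larger core goes with the lower number.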